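The compounds below may be only part of what the source reports. "The series", "measured", "known", "first", "only" and "open" are said of these compounds alone.

Compound 1 `COc1ccc(-c2ccc3ncnc(NCCN4CCCCC4)c3c2)cc1C(N)=O`: 29400 nM
Compound 2 `COc1ncc(-c2ccc3ncnc(NCCN4CCCCC4)c3c2)cc1C#N`: 2680 nM
Compound 3 `COc1ccc(-c2ccc3ncnc(NCCN(C)C)c3c2)cn1`: 15900 nM

In a functional assay on HCT-116 cells (Homo sapiens) for antiproliferative activity, read by MTT assay, with a stated time of 72 h (a higher number here means a weaker inhibitor, a lower number a stronger inhibitor), compound 2 gives the lowest number of the three, and its gaps to compound 3 and to compound 1 both lie beyond the scatter, so it is the strongest inhibitor measured here. Compound 4 `COc1ccc(-c2ccc3ncnc(NCCN4CCCCC4)c3c2)cn1` has not been measured. It differs from compound 2 in one place: hydrogen in place of cyano on an aromatic carbon. For the measured compounds named here, no pair of measured compounds isolates this change, but compound 3 also carries hydrogen at that position and gives 15900 nM, far weaker than compound 2. The step in this assay from compound 2 to compound 4 is therefore expected to be a rise beyond the scatter, a 4.5-fold higher number from compound 2 to compound 4 (0.65 log units; beyond the scatter). Compound 4 is expected to give about 12000 nM, within 4000 nM to 40000 nM.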

Compound 4, half-maximal inhibitory concentration: 22200 nM
Beside the measured number, compound 4's estimate is 1.9-fold (0.27 log units) below it; the measured number falls inside the stated range.
By their numbers in this assay, from the lowest: compound 2; then compounds 3, 4 and 1 (each within the scatter of the next).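

Replacing cyano with hydrogen on the aromatic carbon ortho to the methoxy group gives an 8.3-fold higher number from compound 2 to compound 4 (0.92 log units; beyond the scatter) in this assay, a direct comparison showing that, with the piperidin-1-yl chain in place, the potency of compound 2 depends on this nitrile. Changing dimethylamino to piperidin-1-yl gives a 1.4-fold higher number from compound 3 to compound 4 (0.14 log units; within the scatter) in this assay, so this chain change has no readable effect when hydrogen occupies that carbon. No available measurement explains the nitrile step. On these data alone, whether a chlorine atom or a methyl group at this carbon would match the nitrile remains open. Also open, as far as these compounds go, is whether the nitrile would give a similar step alongside the dimethylamino chain.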